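A few compounds are considered here, and "the series" means these few. Any claim that something is new, unique, unknown or untested is made for them only; others in the source may bear on it.

Compound 2 `C=CCc1cc(C(C)=O)c(O)cc1OCC#N` gives 20% in an assay on isolated protein for inhibition of leukotriene B4 receptor 1 (Homo sapiens), tested at 10 uM (on this read-out higher numbers stand for more inhibition at the one concentration tested (going by the name of the read-out) and lower numbers for less inhibition), the lowest of the three numbers shown. Compound 3 `CCc1cc(C(C)=O)c(O)cc1OCCCCCCC(C)(C)C#N` gives 65% and compound 1 `CCCc1cc(C(C)=O)c(O)cc1OCCCCC#N` gives 84%; both gaps to compound 2 lie beyond the scatter. Within the data shown here, no two measured compounds differ in a single place, so no isolated step is known yet. Compound 4 `C=CCCCCOc1cc(O)c(C(C)=O)cc1CC=C` differs from compound 2 by pent-4-en-1-yl in place of cyano on a saturated chain carbon bound to an oxygen on an aromatic ring. Compound 1 and compound 3 give the higher numbers of the set, and each bears the nitrile at the end of a longer chain, but neither is a one-place comparison with compound 2, so direction is only loosely suggested. The expected step from compound 2 to compound 4 is a number 40 percentage points higher from compound 2 to compound 4 (beyond the scatter), upward beyond the scatter. Compound 4 is estimated at 60%, with a range from 35% to 85%.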

Compound 4, a percentage reported as inhibition, at one concentration (the size of the read-out at that concentration, not a potency): 73%
Beside the measured number, compound 4's estimate is 13 percentage points below it; measured number inside the range.
By their numbers in this assay, from the lowest: compound 2; then compounds 3 and 4 (each within the scatter of the next); then compound 1.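

Among these compounds, the first one-place step in this assay is a number 53 percentage points higher from compound 2 to compound 4 (beyond the scatter) on replacing cyano with pent-4-en-1-yl on a saturated chain carbon bound to an oxygen on an aromatic ring. In this single pair, the nitrile is not needed at this place for a high number. No measurement given here accounts for the rise.

From the compounds shown here alone, whether the rise follows the longer chain or its terminal double bond stays open, and a saturated hexyl chain at this place would separate the two. Going by these compounds, how a carboxylic acid or an amine at the chain end would read also stays open.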